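The source may report more compounds than this note shows. Statements on the series, on what has been measured and on what is new or still open speak of the compounds shown alone.

Measured compounds and values:

Compound 1 `ClCc1ccc(Cn2cnc3nc(Cl)nc(Cl)c32)cc1` gives 9120 nM in a functional assay on SK-MEL-5 cells (Homo sapiens) for cytotoxicity, read by sulforhodamine B assay, with a stated time of 48 h; a lower number here means a stronger inhibitor of growth, a higher number a weaker inhibitor of growth.
Compound 2 `ClCc1ccccc1Cn1cnc2ncnc(Cl)c21` gives 4070 nM in this assay.
Compound 3 `ClCc1ccccc1Cn1cnc2nc(Cl)nc(Cl)c21` gives 2180 nM in this assay.

Compounds 2 and 3 differ in one place only: hydrogen in place of chloro on an aromatic carbon. Across this change the measurement moved a 1.9-fold higher number from compound 3 to compound 2 (0.27 log units; within the scatter), so the two numbers cannot be told apart with confidence. Compound 1 and compound 3 share the same atoms joined differently; the difference between the two cores is not broken down here. Compound 1 has the highest number of the three, and its gaps to compound 2 and to compound 3 lie beyond the scatter.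

Compound 4 `ClCc1ccc(Cn2cnc3ncnc(Cl)c32)cc1` has not been measured. It is related to compound 1 by hydrogen in place of chloro on an aromatic carbon, which is the same change seen between compound 3 and compound 2, at a place described in the same words. Because the earlier change gave a 1.9-fold higher number from compound 3 to compound 2 (0.27 log units; within the scatter), the expected step of a 1.6-fold higher number from compound 1 to compound 4 (0.22 log units; within the scatter) is taken to be of similar size, though with wide uncertainty since that earlier step itself lay within the scatter. On this basis compound 4 is estimated at 15000 nM in this assay, with a likely range from 7000 nM to 35000 nM.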

Compound 4, concentration for total growth inhibition: 12000 nM
Beside the measured number, compound 4's estimate is 1.3-fold (0.10 log units) above it; the range from low to high includes it.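

In this assay, putting hydrogen in place of the chloro group between two ring nitrogen atoms gives a 1.3-fold higher number from compound 1 to compound 4 (0.12 log units; within the scatter), so compound 1 and compound 4 cannot be told apart with confidence. Set beside the same change on the other core, the new step shows no sign that the two cores respond differently: the same change on two cores in this assay, a 1.9-fold higher number (0.27 log units; within the scatter) from compound 3 to compound 2 and a 1.3-fold higher number (0.12 log units; within the scatter) from compound 1 to compound 4, 1.4-fold (0.15 log units) apart, within the scatter of two such steps. This agreement is a modest finding: it shows that the change left no clear mark on either core, but it does not show that the two cores respond identically, and two small steps cannot establish a rule for the whole series.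

The compounds shown carry only chloro or hydrogen at this place, so it remains open whether an amine, a methoxy group or a longer chain there would shift the number clearly. Also open, from the compounds shown here alone, is what would follow if the chloromethyl group on all four compounds gave way to a methyl group or a carboxylic acid.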